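The source may report more compounds than this note shows. Statements on the series, on what has been measured and on what is new or still open speak of the compounds shown alone.

Working notes on the series in a toxicity assay on HUVEC cells (Homo sapiens) for inhibition; a lower number here means a stronger inhibitor of growth, a higher number a weaker inhibitor of growth. Compound 1 `Cc1ccc(C)c(N2CCN(C(=O)c3oc(C)nc3-c3ccccc3)CC2)c1` gives 1.73 ug/mL and compound 2 `COc1cc(OC)cc(N2CCN(C(=O)c3oc(C)nc3-c3ccccc3F)CC2)c1` gives 0.118 ug/mL. Compound 3 `Cc1cc(C)cc(N2CCN(C(=O)c3oc(C)nc3-c3ccccc3)CC2)c1` gives 0.356 ug/mL, the second highest of the three numbers, with compound 2 lower and compound 1 higher, both gaps beyond the scatter.

Compound 4 `Cc1nc(-c2ccccc2)c(C(=O)N2CCN(c3cccc(F)c3)CC2)o1` is not yet measured in this assay. Its change is 3-fluorophenyl in place of 3,5-dimethylphenyl on an amine nitrogen in a ring.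

Among the compounds with values here, one measured step touches this place: a 4.9-fold lower number from compound 1 to compound 3 (0.69 log units; beyond the scatter), a modest step beyond the scatter that exchanges 2,5-dimethylphenyl for 3,5-dimethylphenyl. Within the data shown here, it shows that the group at this place can move the number, but no measured step replaces a dimethylphenyl with a fluorophenyl. Compound 2 differs from compound 3 in more than one place and isolates nothing here. No step beyond the scatter is therefore expected, with a slight lean towards a higher number.

The estimate amounts to an expected 1.4-fold higher number from compound 3 to compound 4 (0.15 log units; within the scatter). For compound 4 the estimated value is 0.5 ug/mL, with an expected range of 0.15 ug/mL to 1.6 ug/mL.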

Compound 4, concentration for 50% growth inhibition: 1.05 ug/mL
Beside the measured number, compound 4's estimate is 2.1-fold (0.32 log units) below it; the range from low to high includes it.
By their numbers in this assay, from the lowest: compound 2; then compound 3; then compounds 4 and 1 (each within the scatter of the next).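

In this assay, within the data shown here, this is the first measured exchange of a dimethylphenyl for a fluorophenyl on the amine nitrogen in the ring, and a 2.9-fold higher number from compound 3 to compound 4 (0.47 log units; beyond the scatter) shows that the exchange can move the number beyond the scatter. Starting from 2,5-dimethylphenyl, the same 3-fluorophenyl gives a 1.6-fold lower number from compound 1 to compound 4 (0.22 log units; within the scatter) and stays within the scatter, so among the three compounds that differ only at this place, compound 3 alone stands apart with the lower number. Nothing available bears on why these numbers differ.

The compounds shown leave open whether compound 3's lower number depends on having two groups on the phenyl ring or on the methyl groups themselves. 3-Methylphenyl, 3-chlorophenyl and 3,5-difluorophenyl at this place would help separate these possibilities.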